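The source may report more compounds than this note shows. Statements on the series, on what has been measured and on what is new or still open speak of the compounds shown alone.

Compound 1 `COc1ccc2c(/C=C(\C)C(=O)c3cc(OC)c(OC)c([Se]C)c3)cn(C)c2c1`: 32 nM
Compound 2 `COc1cc(C(=O)/C=C/c2c[nH]c3ccccc23)cc([N+](=O)[O-])c1OC`: 1350 nM
Compound 3 `COc1cc(C(=O)/C=C/c2cn(C)c3ccccc23)cc(N)c1OC`: 668 nM

In a functional assay on HeLa cells (Homo sapiens) for antiproliferative activity, read by MTT assay, with a stated time of 48 h (on this read-out higher numbers stand for weaker inhibition and lower numbers for stronger inhibition), compound 1 has the lowest of the three numbers (32 nM), beyond the scatter from both others. Compound 4 `COc1cc(C(=O)/C(C)=C/c2cn(C)c3ccccc23)cc([Se]C)c1OC` keeps the core of compound 1 with one change, hydrogen in place of methoxy on an aromatic carbon. Going by the values given here, no measured pair isolates this change. Compound 3 (668 nM) and compound 2 (1350 nM) also lack that methoxy, but they differ from compound 1 elsewhere too, so they offer only a loose hint. A moderate move toward weaker inhibition is expected, an estimated step of a 2.8-fold higher number from compound 1 to compound 4 (0.45 log units; beyond the scatter) in this assay. For compound 4 the estimated value is 90 nM, with an expected range of 20 nM to 400 nM.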

Compound 4, half-maximal inhibitory concentration: 63 nM
Beside the measured number, compound 4's estimate is 1.4-fold (0.15 log units) above it; the measured number falls inside the stated range.
By their numbers in this assay, from the lowest: compounds 1 and 4 (each within the scatter of the next); then compound 3; then compound 2.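

In this assay, going by these compounds alone, the first pair that isolates this change shows that hydrogen in place of methoxy on an aromatic carbon gives a 2.0-fold higher number from compound 1 to compound 4 (0.29 log units; within the scatter), so the two compounds cannot be told apart. Within the data shown here, on this core, then, the methoxy at this position is not required for a number in this range, something the loose comparison with the earlier compounds could not show. No available evidence bears on this result. The compounds shown leave open whether a hydroxyl, an amine or a longer alkoxy chain on this carbon would stay in the same range.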